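From a sulfonyl chain to a methylsulfonyl carbamoyl chain

A few compounds are considered here, and "the series" means these few. Any claim that something is new, unique, unknown or untested is made for them only; others in the source may bear on it.

Three compounds with a shared core have numbers in a functional assay for inhibition, with Homo sapiens as the target; on this read-out lower numbers stand for stronger inhibition and higher numbers for weaker inhibition. Compound 1 `O=C(O)CCCCCCCCn1nc(-c2ccccc2)c(-c2ccccc2)c1-c1ccccc1` gives 400 nM, compound 2 `O=C(O)C[S+]([O-])CCCCCCn1nc(-c2ccccc2)c(-c2ccccc2)c1-c1ccccc1` gives 6500 nM, and compound 3 `O=C(O)CS(=O)(=O)CCCCCCn1nc(-c2ccccc2)c(-c2ccccc2)c1-c1ccccc1` gives 22000 nM. That last value is the highest of the three, so compound 3 is the weakest inhibitor so far.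

The chain clearly matters. The measured steps are a 16-fold higher number from compound 1 to compound 2 (1.21 log units; beyond the scatter) and a 55-fold higher number from compound 1 to compound 3 (1.74 log units; beyond the scatter), both large, and a 3.4-fold higher number from compound 2 to compound 3 (0.53 log units; beyond the scatter), a modest one.

Compound 4 `CS(=O)(=O)NC(=O)CCCCCCCCn1nc(-c2ccccc2)c(-c2ccccc2)c1-c1ccccc1` has not yet been measured. Its difference from compound 3 is 2-((methylsulfonyl)carbamoyl)ethyl in place of (carboxymethyl)sulfonyl on a saturated chain carbon, six bonds along the chain from an aromatic nitrogen. The change lies on a saturated chain carbon, six bonds along the chain from an aromatic nitrogen.

Like compound 1, compound 4 has an ethyl link at this place, not a sulfonyl. The most relevant evidence is therefore the large 55-fold higher number from compound 1 to compound 3 (1.74 log units; beyond the scatter), read in reverse. However, no measured compound carries the new (methylsulfonyl)carbamoyl end, so only part of that gain is expected.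

The expected change in this assay is a 15-fold lower number from compound 3 to compound 4 (1.17 log units; beyond the scatter), a clear move toward a lower number. Compound 4 is estimated at 1500 nM, with an expected range of 300 nM to 8000 nM.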

Compound 4, half-maximal inhibitory concentration: 5900 nM
Beside the measured number, compound 4's estimate is 3.9-fold (0.59 log units) below it; low and high end bracket the measured number.
By their numbers in this assay, from the lowest: compound 1; then compounds 4 and 2 (each within the scatter of the next); then compound 3.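

The end of the chain turns out to matter as much as the chain itself: methanesulfonamido in place of hydroxy on a carbonyl carbon, with the chain left untouched, gives a 15-fold higher number from compound 1 to compound 4 (1.17 log units; beyond the scatter) in this assay, so an all-carbon chain does not by itself bring back the low number. Replacing (carboxymethyl)sulfonyl with 2-((methylsulfonyl)carbamoyl)ethyl recovers only part of the lost ground, with a 3.7-fold lower number from compound 3 to compound 4 (0.57 log units; beyond the scatter), while a 1.1-fold lower number from compound 2 to compound 4 (0.04 log units; within the scatter) shows that two quite different structures can give indistinguishable numbers in this assay. Nothing available here explains why the new end group gives a higher number than the carboxylic acid does on the same chain.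

The compounds shown leave open whether another acid-like end, such as a tetrazole or a primary amide, would stay as close to compound 1 on this chain, and whether a longer or shorter chain would alter the picture. They also leave open how the methanesulfonamido end would behave on a chain carrying a sulfonyl group, so the effects of the chain and of its end cannot yet be told apart as independent contributions.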